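The compounds below may be only part of what the source reports. "The series", "measured", "known", "first", "only" and "open" are said of these compounds alone.

Working notes on the shared core, the series so far measured in a functional assay on A549 cells (Homo sapiens) for antiproliferative activity, read by CCK-8 assay, with a stated time of 48 h; on this read-out higher numbers stand for weaker inhibition and lower numbers for stronger inhibition.

Compound 1 `CC(C)CSc1n[nH]c(-n2[se]c3ccccc3c2=O)n1` gives 37800 nM in this assay. Compound 2 `Cc1ccccc1CSc1n[nH]c(-n2[se]c3ccccc3c2=O)n1` gives 9720 nM. Compound 3 `CCCCCCSc1n[nH]c(-n2[se]c3ccccc3c2=O)n1` gives 20300 nM. Of the three numbers, compound 3 stands second highest: its nearest neighbour is compound 1, and the step from compound 1 to compound 3 is within the scatter a 1.9-fold lower number from compound 1 to compound 3 (0.27 log units; within the scatter); the step from compound 2 to compound 3 is modest but beyond it a 2.1-fold higher number from compound 2 to compound 3 (0.32 log units; beyond the scatter). For comparison, the step from compound 1 to compound 2 is a 3.9-fold lower number from compound 1 to compound 2 (0.59 log units; beyond the scatter).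

Compound 4 `CC(C)Sc1n[nH]c(-n2[se]c3ccccc3c2=O)n1` is the next member and is not yet measured. Against compound 3 the change is isopropyl in place of hexyl on a sulfur. Within the data shown here, the only measured step that bears on a change of chain length on this side of the sulfur is the one from compound 1 to compound 3, a 1.9-fold lower number from compound 1 to compound 3 (0.27 log units; within the scatter), and it stayed within the scatter. On that basis a step of about a 1.5-fold higher number from compound 3 to compound 4 (0.17 log units; within the scatter) in this assay is expected, that is, no clear change beyond the scatter. Compound 4 is therefore estimated at 30000 nM, with a range of 12000 nM to 75000 nM.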

Compound 4, half-maximal inhibitory concentration: 36600 nM
Estimate against measurement, compound 4: 1.2-fold (0.09 log units) below, and the stated range covers the measured number.
By their numbers in this assay, from the lowest: compound 2; then compounds 3, 4 and 1 (each within the scatter of the next).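

In this assay isopropyl in place of hexyl on a sulfur (a 1.8-fold higher number from compound 3 to compound 4 (0.26 log units; within the scatter)) and isopropyl in place of isobutyl (a 1.0-fold lower number from compound 1 to compound 4 (0.01 log units; within the scatter)) both stay within the scatter, so compounds 1, 3 and 4 show no clear separation among their saturated chains, branched or straight. Among these compounds, compound 2 goes against this flat picture, since isopropyl in place of 2-methylbenzyl (a 3.8-fold higher number from compound 2 to compound 4 (0.58 log units; beyond the scatter)) lies beyond the scatter, and its 2-methylbenzyl is the only group on the sulfur here that carries a ring. No measurement available here accounts for this difference.

Still open, going by these compounds, is whether a plain benzyl group, without the methyl, would stay with compound 2 or fall in with the saturated chains. Equally open, on these data alone, is how a chain longer than hexyl, or one ending in an amine or a carboxylic acid, would read in this assay on this sulfur.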